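From trifluoroethyl to oxan-4-yl on a carbonyl carbon

The compounds below may be only part of what the source reports. "The series", "measured", "known", "first", "only" and "open" are said of these compounds alone.

Compound 1 `CCC(=O)N[C@@H](C)c1ccc(NC(=O)[C@H]2C[C@@H]2c2cccnc2)cc1`: 22 nM
Compound 2 `C[C@H](NC(=O)CC(F)(F)F)c1ccc(NC(=O)[C@H]2C[C@@H]2c2cccnc2)cc1`: 18 nM

In a functional assay on COR-L23 cells (Homo sapiens) for antiproliferative activity, read by CellTiter-Glo, with a stated time of 4 days (a higher number here means a weaker inhibitor, a lower number a stronger inhibitor), compound 2 gives 18 nM, level within the scatter with compound 1 at 22 nM. Compound 3 `C[C@H](NC(=O)C1CCOCC1)c1ccc(NC(=O)[C@H]2C[C@@H]2c2cccnc2)cc1` departs from compound 2 by oxan-4-yl in place of 2,2,2-trifluoroethyl on a carbonyl carbon, with oxan-4-yl in place of 2,2,2-trifluoroethyl on a carbonyl carbon. For the measured compounds named here, one measured step bears on this: a 1.2-fold lower number from compound 1 to compound 2 (0.09 log units; within the scatter), which changed the group on the same carbonyl carbon and stayed within the scatter. Going by the values given here, no measured compound has a ring there, so the guide is indirect. The expected change is a 1.4-fold higher number from compound 2 to compound 3 (0.14 log units; within the scatter), nothing beyond the scatter. Compound 3 is expected at 25 nM, with an estimated range of 8 nM to 80 nM.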

Compound 3, half-maximal inhibitory concentration: 7 nM
For compound 3 the middle estimate is 3.6-fold (0.55 log units) above the measured one; the whole stated range lies above it.
By their numbers in this assay, from the lowest: compound 3; then compounds 2 and 1 (each within the scatter of the next).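

In this assay, for the compounds shown here, the replacement of either open chain on this carbonyl carbon by oxan-4-yl gives a 2.6-fold lower number from compound 2 to compound 3 (0.41 log units; beyond the scatter) and a 3.1-fold lower number from compound 1 to compound 3 (0.50 log units; beyond the scatter) as the first steps here beyond the scatter. The position therefore responds to the group it carries, although ethyl and 2,2,2-trifluoroethyl did not separate there. No evidence is at hand on the cause of this gain.

The compounds shown leave open whether the ring or its oxygen carries the step. Cyclohexyl or piperidin-4-yl on the same carbonyl carbon would bear on that question.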